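A Fluorophenyl Swap on a Shared Core

The source may hold more compounds than are shown below. What is called first, only, known or untested is meant among the compounds shown, and "the series" means these compounds.

Three compounds built on one shared core have been taken through an ADME assay on MT4 cells (Homo sapiens) for cytotoxicity, read by MTT assay, with a stated time of 5 days; a higher number here means that more compound is tolerated, a lower number that less compound is tolerated. Compound 1 `O=C1N(Cc2ccccc2Cl)c2cccn2S(=O)(=O)N1Cc1cccc(Br)c1` reaches only a limit of this assay: in this assay compound 1 gives > 260000 nM, which is a limit and not a number, as recorded in the limit of > 260000 nM in this assay, at which 1 of the 3 values shown sits. Compound 2 `O=C1N(Cc2cccc(Cl)c2)c2cccn2S(=O)(=O)N1Cc1cccc(F)c1` gives 208000 nM in this assay. Compound 3 `CC(C)=CCN1C(=O)N(Cc2ccccc2)S(=O)(=O)n2cccc21` gives 226000 nM in this assay; this is the higher of the two numbers shown, yet its nearest neighbour, compound 2, lies within the usual scatter, so the two are best read as alike. Going by the values given here, no pair of measured compounds differs in only one place, so no measured step is available to guide the next one.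

Compound 4 `O=C1N(Cc2ccc(F)cc2)c2cccn2S(=O)(=O)N1Cc1ccccc1` has not yet been measured. It differs from compound 3 by 4-fluorophenyl in place of 2-methylprop-1-en-1-yl on a saturated chain carbon bound to an amide-type nitrogen in a ring. Among the compounds with values here, with no measured step to lean on, and with compounds 2 and 3 sitting close together while compound 1 sits at a limit, only a small change is expected: the estimated step of a 1.0-fold lower number from compound 3 to compound 4 (0.01 log units; within the scatter) is not expected to go beyond the scatter in either direction. Compound 4 is accordingly expected to give about 220000 nM in this assay, within an estimated range from 120000 nM to 300000 nM.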

Compound 4, half-maximal cytotoxic concentration: 150000 nM
For compound 4 the middle estimate is 1.5-fold (0.17 log units) above the measured one; measured number inside the range.
By their numbers in this assay, from the lowest: compounds 4, 2 and 3 (each within the scatter of the next). At a limit, above all of these: compound 1.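

Going by these compounds alone, the first measured step on the shared core puts 4-fluorophenyl in place of 2-methylprop-1-en-1-yl on a saturated chain carbon bound to an amide-type nitrogen in a ring, and in this assay it reads a 1.5-fold lower number from compound 3 to compound 4 (0.18 log units; within the scatter) at this position. Within the data shown here, an open chain with one double bond outside aromatic rings can therefore give way to a six-membered aromatic ring of carbon only, with 7 heavy atoms entering where 4 leave, without the number moving beyond the scatter, something the earlier compounds, which differ from one another in more than one place, could not show. Nothing in the data shown bears on why the number stays within the scatter across this change.

From the compounds shown here alone, whether an amine, a carboxylic acid or a longer chain in this same place would move the number beyond the scatter remains open. Going by these compounds, it also remains open whether the fluorine of the 4-fluorophenyl group plays any part, as a plain phenyl group in its place would be needed to read that step.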